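A Chloro Group Added to Compound 2

The compounds below may be only part of what the source reports. "The series", "measured", "known", "first", "only" and "open" are said of these compounds alone.

Compound 2 `O=C(O)COc1ccccc1C#Cc1ccccc1Cl` is a diaryl alkyne with a carboxymethoxy group on one ring and a chloro group on the other. In an assay on CHO cells for displacement of a labelled ligand from prostaglandin D2 receptor 2 (Homo sapiens), read by scintillation counting (on this read-out higher numbers stand for weaker inhibition and lower numbers for stronger inhibition), compound 2 gives 747 nM. Among the three measured compounds it stands second highest: compound 1 `O=C(O)COc1cc(F)ccc1C#Cc1ccccc1Cl`, which gives 4780 nM, lies above it, while compound 3 `COCc1ccc(C#Cc2cc(Cl)ccc2OCC(=O)O)c(F)c1`, which gives 22 nM, lies far below it.

Compound 4 `O=C(O)COc1ccc(Cl)cc1C#Cc1ccccc1Cl` is the next compound. It differs from compound 2 by chloro in place of hydrogen on an aromatic carbon.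

For the measured compounds named here, only one step among the measured compounds can be compared. Going a 6.4-fold lower number from compound 1 to compound 2 (0.81 log units; beyond the scatter), so removing a fluoro group from the carboxymethoxy-bearing ring made the number fall. Going by the values given here, no measured pair shows a chloro group entering at this place on an otherwise identical scaffold. Compound 3 also carries a chloro group on the ring that bears the carboxymethoxy group and gives a much lower number than compound 2, but it differs from compound 2 in the other ring as well, so its value is only a loose pointer.

On this basis a modest drop is expected, with a 3.0-fold lower number from compound 2 to compound 4 (0.48 log units; beyond the scatter). Compound 4 is therefore estimated at 250 nM in this assay , within a range from 60 nM to 1000 nM.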

Compound 4, inhibition constant: 28 nM
Compound 4: the middle estimate sits 8.9-fold (0.95 log units) above what was measured; the whole stated range lies above it.
By their numbers in this assay, from the lowest: compounds 3 and 4 (each within the scatter of the next); then compound 2; then compound 1.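

In this assay, a single chloro group on the aromatic carbon para to the carboxymethoxy group gives a 27-fold lower number from compound 2 to compound 4 (1.43 log units; beyond the scatter), so a change of one heavy atom at this position is enough for a large step. For the compounds shown here, until now, the only single change on this ring was the fluoro group of compound 1, and removing it gave a 6.4-fold lower number from compound 1 to compound 2 (0.81 log units; beyond the scatter), so there the added group went with a higher number, whereas here it goes with a lower one. Those two steps differ in both the group and the carbon, so together they show only that a substituent on this ring does not shift the number the same way in every case, and no measurement shown here accounts for the size of the new step.

As far as these compounds go, it remains open whether a bromo, methyl or methoxy group on this same carbon would lower the number as far as chloro does, or whether chloro would do so on another carbon of the ring. From the compounds shown here alone, it is also open how much the same chloro group contributes when the other ring carries different groups, as it does in compound 3.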